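Dropping the methylcarbamoyl: compound 3 to compound 4

The source may report more compounds than this note shows. Statements on the series, on what has been measured and on what is new or still open speak of the compounds shown alone.

In a functional assay on BaF3 cells (Mus musculus) for antiproliferative activity (on this read-out higher numbers stand for an effect only at larger amounts of compound and lower numbers for an effect already at smaller amounts), compound 3 (`CCN1CCN(Cc2ccc(NC(=O)c3ccc(C)c(C#Cc4ccc(C(=O)NC)nc4)c3)cc2C(F)(F)F)CC1`) stands highest of the three measured numbers at 3980 nM while compound 1 (`CCN1CCN(Cc2ccc(NC(=O)c3ccc(C)c(C#Cc4cccnc4)c3)cc2C(F)(F)F)CC1`) gives 1590 nM and compound 2 (`CCN1CCN(Cc2ccc(NC(=O)c3ccc(C)c(C#Cc4ccc(NC(=O)C5CC5)nc4)c3)cc2C(F)(F)F)CC1`) gives 1800 nM as its number. Compound 4 (`CCN1CCN(Cc2ccc(NC(=O)c3ccc(C)c(C#Cc4cncnc4)c3)cc2C(F)(F)F)CC1`) has pyrimidin-5-yl in place of 6-(methylcarbamoyl)pyridin-3-yl on a triple-bonded carbon and so carries no methylcarbamoyl. The closest measured precedent is a 2.5-fold higher number from compound 1 to compound 3 (0.40 log units; beyond the scatter) on adding methylcarbamoyl. Also modest is a 2.2-fold higher number from compound 2 to compound 3 (0.34 log units; beyond the scatter) while a 1.1-fold higher number from compound 1 to compound 2 (0.05 log units; within the scatter) stays within the scatter. Going by the values given here, no measured compound carries pyrimidin-5-yl, so that part of the change has no precedent. The expected step in this assay is modest and toward a lower number, estimated as a 2.2-fold lower number from compound 3 to compound 4 (0.34 log units; beyond the scatter) for now. Compound 4 is estimated at 1800 nM with an expected range of 650 nM to 5000 nM on this read-out.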

Compound 4, half-maximal effective concentration: 2190 nM
Compound 4: middle estimate off by 1.2-fold (0.09 log units), on the low side, and the stated range covers the measured number.
By their numbers in this assay, from the lowest: compounds 1, 2, 4 and 3 (each within the scatter of the next, the first and the last beyond it).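

In this assay pyrimidin-5-yl on the triple-bonded carbon stays within the scatter of all three earlier groups there (a 1.8-fold lower number from compound 3 to compound 4 (0.26 log units; within the scatter)) (a 1.2-fold higher number from compound 2 to compound 4 (0.09 log units; within the scatter)) (a 1.4-fold higher number from compound 1 to compound 4 (0.14 log units; within the scatter)). Going by these compounds alone, this position therefore accepts a six-membered aromatic ring with 2 hetero atoms and no methylcarbamoyl without a step beyond the scatter from any compound measured so far. No evidence bears on the reason for this result. Still open, from the compounds shown here alone, is whether an amine or a carboxylic acid on the pyridin-3-yl group would give a number beyond the scatter of compound 1.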